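From fluoro to 4-methylpiperazin-1-yl on compound 2

This account rests on a few compounds, and the source may have more. Where it says the series, first, only, none or still open, it means among the compounds named here.

Compound 1 `CCOc1ccc(Nc2cc(NC(=O)c3ccccc3)ncn2)cc1` gives 6540 nM here
Compound 2 `COc1ccc(OC)c(Nc2cc(Nc3ccc(F)cc3)ncn2)c1` gives > 30000 nM here
Compound 3 `Clc1ccc(Nc2cc(Nc3cccc(Cl)n3)ncn2)cc1` gives > 30000 nM here

All three results come from a functional assay on A-431 cells (Homo sapiens) for antiproliferative activity, read by MTT assay, with a stated time of 72 h (on this read-out higher numbers stand for weaker inhibition and lower numbers for stronger inhibition), and only compound 1 has a true number. Compound 2 stands at the limit of > 30000 nM in this assay, at which 2 of the 3 values shown sit, and this is a limit, not a number. Compound 4 `COc1ccc(OC)c(Nc2cc(Nc3ccc(N4CCN(C)CC4)cc3)ncn2)c1` differs from it by 4-methylpiperazin-1-yl in place of fluoro on an aromatic carbon in one place: 4-methylpiperazin-1-yl in place of fluoro on an aromatic carbon, para to a large group. Among the measured compounds shown here, no measured pair shows this change. A moderate gain in inhibition, beyond the scatter, is nevertheless expected in this assay and a result at the limit remains possible. The expected change is an at least 3.3-fold lower number from compound 2 to compound 4 (0.52 log units; beyond the scatter) on this estimate. Compound 4 is estimated at 9000 nM with an expected range from 2500 nM to 30000 nM in this read-out.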

Compound 4, half-maximal inhibitory concentration: > 30000 nM
Compound 4: only a limit was reported; the forecaster's own chance of this, stated with the estimate: 35%; at least 3.3-fold (0.52 log units) between middle value and limit.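

Among the compounds shown here, compound 2 and compound 4 both stand at a limit, not a number, in this assay, and no step between them can be read. From the compounds shown here alone, whether 4-methylpiperazin-1-yl in place of fluoro changes inhibition at all stays open.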